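A few compounds are considered here, and "the series" means these few. Any claim that something is new, unique, unknown or untested is made for them only; others in the source may bear on it.

Values in a functional assay on HCT-15 cells (Homo sapiens) for cytotoxicity, read by sulforhodamine B assay, with a stated time of 48 h; a lower number here means a stronger inhibitor, a higher number a weaker inhibitor:
Compound 1 `CC1(C)CNC(=O)c2cc(-c3ccc([N+](=O)[O-])cc3)n(-c3ccc(Cl)cc3)c2C1`: 20000 nM
Compound 2 `CC1(C)CNC(=O)c2cc(-c3ccc([N+](=O)[O-])cc3)n(-c3ccc(Br)cc3)c2C1`: > 100000 nM (a limit)
Compound 3 `CC1(C)CNC(=O)c2cc3n(c2C1)CCc1ccccc1-3`: > 100000 nM (a limit)

Compound 3 stands at > 100000 nM, which is a limit and not a number. It therefore rests at the limit of > 100000 nM in this assay, at which 2 of the 3 values shown sit. Compound 4 `CC1(C)CNC(=O)c2cc3n(c2C1)CCc1cc(Br)ccc1-3` differs from it by one change: bromo in place of hydrogen on an aromatic carbon. Within the data shown here, the only measured step involving bromo is an at least 5.0-fold higher number from compound 1 to compound 2 (0.69 log units; beyond the scatter). That step puts bromo in place of chloro, not hydrogen, so it bears only loosely on this change, and it offers no sign of a gain. No step beyond the scatter is therefore expected in this assay. The expected step is a number no higher from compound 3 to compound 4 (the limit leaves the size open). For compound 4 the estimated value is 100000 nM, with an expected range from 25000 nM to 200000 nM.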

Compound 4, half-maximal inhibitory concentration: 25600 nM
For compound 4 the middle estimate is 3.9-fold (0.59 log units) above the measured one, and the stated range covers the measured number.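

In this assay, bromo in place of hydrogen on an aromatic carbon of the fused system of four rings gives an at least 3.9-fold lower number from compound 3 to compound 4 (0.59 log units; beyond the scatter), so a single bromine at this carbon is enough to bring a measurable value. The earlier bromo step ran the other way, an at least 5.0-fold higher number from compound 1 to compound 2 (0.69 log units; beyond the scatter), but it replaced chloro on a different core, so bromo shows no single direction across these compounds. The size of the new step stays a minimum, as compound 3 rests at a limit: the limit of > 100000 nM in this assay, at which 2 of the 4 values shown sit.

As far as these compounds go, whether chloro, methoxy or an amine at this carbon would do the same remains open. So does whether bromo on another carbon of this ring would match it.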